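Second hydroxymethyl on the shared core

The compounds below may be only part of what the source reports. "The series", "measured", "known", "first", "only" and "open" are said of these compounds alone.

Measured so far:
Compound 1, `Cc1c(CO)cc2n1[C@@H](c1ccccc1)SC2`: 4300 nM
Compound 2, `Cc1c(CO)cc2n1CSC2`: 156000 nM

Two compounds have been run in a functional assay on MCF7 cells (Homo sapiens) for cytotoxicity, read by MTT assay, with a stated time of 48 h; a higher number here means a weaker inhibitor, a lower number a stronger inhibitor. Compound 2 stands at the higher of the two numbers, giving 156000 nM. Compound 1 gives 4300 nM, a number that lies beyond the scatter below that of compound 2; the two structures differ at more than one place, so nothing is counted as a single step between them.

Compound 3, `Cc1c(CO)c(CO)c2n1CSC2`, is the next compound to be measured. Relative to compound 2 the change is hydroxymethyl in place of hydrogen on an aromatic carbon. For the measured compounds named here, no measured pair shows this kind of change, and the one comparison available, compound 1 against compound 2, concerns a different part of the shared core. The step from compound 2 to compound 3 is expected to be small, a 1.4-fold lower number from compound 2 to compound 3 (0.15 log units; within the scatter), leaning toward a lower number but not expected to reach beyond the scatter. For compound 3 the estimate is 110000 nM, with a range from 35000 nM to 350000 nM. With compound 2 already at a high number, a limit rather than a number remains possible for compound 3.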

Compound 3, half-maximal inhibitory concentration: 38100 nM
Compound 3: the middle estimate sits 2.9-fold (0.46 log units) above what was measured; the measured number falls inside the stated range.
By their numbers in this assay, from the lowest: compound 1; then compound 3; then compound 2.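

In this assay the step of a 4.1-fold lower number from compound 2 to compound 3 (0.61 log units; beyond the scatter) is the only single-place step shown so far, and it places a modest but real change at this aromatic carbon, two ring bonds from the ring nitrogen. Compound 1 and compound 2 differ at more than one place, so that earlier pair could say nothing about this position or about hydroxymethyl in place of hydrogen. No measurement at hand bears on the reason for this step. Going by these compounds, whether the lower number belongs to hydroxymethyl specifically remains open, since an amine, a carboxylic acid or a longer chain on this aromatic carbon would be needed to separate that group from substitution in general. Also open, on these data alone, is whether the same change would carry over to the core of compound 1, where the number already lies lower, or whether its size depends on the rest of the shared core.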